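A new amide side chain for compound 3

The compounds below may be only part of what the source reports. "The series", "measured", "known", "first", "only" and "open" are said of these compounds alone.

In an ADME assay on L02 cells (Homo sapiens) for cytotoxicity, read by MTT assay, with a stated time of 48 h (on this read-out lower numbers stand for stronger inhibition and higher numbers for weaker inhibition), compound 1 (`CCN(CC)CCNC(=O)c1ccc(C(CC)(CC)c2ccc(OCC(=O)C(C)(C)C)c(C)c2)n1CC`) gives 2500 nM, compound 2 (`CCn1c(C(=O)NCCN)ccc1C(CC)(CC)c1ccc(OCC(=O)C(C)(C)C)c(C)c1`) gives 2500 nM and compound 3 (`CCOC(=O)CN(C)C(=O)c1ccc(C(CC)(CC)c2ccc(OCC(O)C(C)(C)C)c(C)c2)n1CC`) gives 10100 nM. Compound 3 thus has the highest of the three numbers, beyond the scatter from both of the others. The unmeasured compound 4 (`CCN(CC)CCNC(=O)c1ccc(C(CC)(CC)c2ccc(OCC(O)C(C)(C)C)c(C)c2)n1CC`) departs from compound 3 on a carbonyl carbon: (2-(diethylamino)ethyl)amino in place of ((ethoxycarbonyl)methyl)(methyl)amino on a carbonyl carbon.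

For the measured compounds named here, no measured step makes this change. The nearest evidence is no change at the digits printed from compound 1 to compound 2 (within the scatter), a step on the chain that enters here, with amino in place of diethylamino. It shows that the number held when that chain's end was altered. Going by the values given here, compound 1 carries the entering (2-(diethylamino)ethyl)amino group and stands at 2500 nM, but no measured pair isolates the exchange, so this is only a loose guide. A move towards a lower number is therefore expected, reaching only part of the way to compound 1. The estimated change is a 2.5-fold lower number from compound 3 to compound 4 (0.40 log units; beyond the scatter), and its size is uncertain. For compound 4 the expected value is 4000 nM, with an estimated range from 1800 nM to 9000 nM.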

Compound 4, half-maximal inhibitory concentration: 2500 nM
Beside the measured number, compound 4's estimate is 1.6-fold (0.20 log units) above it; the range from low to high includes it.
By their numbers in this assay, from the lowest: compounds 1, 2 and 4 (each within the scatter of the next); then compound 3.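

For the compounds shown here, at this position the whole side chain on the carbonyl carbon was exchanged, and in this assay putting (2-(diethylamino)ethyl)amino in place of ((ethoxycarbonyl)methyl)(methyl)amino gives a 4.0-fold lower number from compound 3 to compound 4 (0.61 log units; beyond the scatter) as the first measured step at this place, so the amide side chain does bear on the number here. The earlier compounds had only shown the end of the entering chain being altered, whereas the other new step, with 1-hydroxy-2,2-dimethylpropyl in place of (tert-butyl)carbonyl, gives no change at the digits printed from compound 1 to compound 4 (within the scatter) and so shows that this far end of the molecule can differ while the (2-(diethylamino)ethyl)amino group stays in place. No measurement given here offers an explanation for either step.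

The compounds shown leave open which part of the leaving group goes with the higher number in compound 3, since its ethyl ester and its methyl on the amide nitrogen change together with the rest of the chain in this exchange. A carboxylic acid in place of that ester, a simple (ethoxycarbonyl)methylamino group on the same carbonyl carbon, or a longer chain ending in diethylamino would each separate these parts.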